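Anilinopyrimidine series: swapping the pyridyl for thiophenyl

The compounds below may be only part of what the source reports. "The series", "measured", "known", "first", "only" and "open" are said of these compounds alone.

Measured so far:
compound 1 `Cc1cc(C)cc(Nc2nccc(-c3ccccn3)n2)c1`, 100 nM
compound 2 `Cc1cccc(Nc2nccc(-c3ccccn3)n2)c1`, 700 nM

In a functional assay for inhibition, with Homo sapiens as the target (a higher number here means a weaker inhibitor, a lower number a stronger inhibitor), compound 1 gives the lower of the two numbers; compound 2 sits a 7.0-fold higher number from compound 1 to compound 2 (0.85 log units; beyond the scatter) away. Compound 3 `Cc1cc(C)cc(Nc2nccc(-c3cccs3)n2)c1` keeps both methyl groups and differs from compound 1 by thiophen-2-yl in place of pyridin-2-yl on an aromatic carbon. For the measured compounds named here, no measured step bears on this change: the only step in hand concerns a methyl on a different ring and says nothing about the heteroaryl. A move beyond the scatter is possible in either direction; the expectation is a modest weakening, with compound 3 estimated at 300 nM (range 60 nM to 1500 nM), a step of a 3.0-fold higher number from compound 1 to compound 3 (0.48 log units; beyond the scatter).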

Compound 3, half-maximal inhibitory concentration: 4300 nM
For compound 3 the middle estimate is 14-fold (1.16 log units) below the measured one; the measured number lies above the stated range.
By their numbers in this assay, from the lowest: compound 1; then compound 2; then compound 3.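

In this assay this position, on an aromatic carbon next to the ring nitrogen, does not tolerate every heteroaryl: thiophen-2-yl in place of pyridin-2-yl gives a large loss (a 43-fold higher number from compound 1 to compound 3 (1.63 log units; beyond the scatter)). The printed step exceeds that for removing one methyl (a 7.0-fold higher number from compound 1 to compound 2 (0.85 log units; beyond the scatter)). The swap changes ring size and hetero atom together, and nothing available explains the loss.

Phenyl or pyridin-3-yl at this position would separate those two changes. On these data alone, whether the methyl step carries over to the thiophen-2-yl compounds also remains open.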